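The source may hold more compounds than are shown below. What is called first, only, known or untested is meant among the compounds shown, and "the series" means these compounds.

Measured so far in a functional assay on A549 cells (Homo sapiens) for antiproliferative activity, read by MTT assay, with a stated time of 48 h; a lower number here means a stronger inhibitor, a higher number a weaker inhibitor (all three values are limits):

- Compound 1 `COc1ccc(N2CCN(Cc3ccc4c(c3O)-c3ccc(cc3O)CCc3ccc(O)c(c3)Oc3ccc(cc3)CC4)CC2)cc1` (> 20000 nM)
- Compound 2 `COc1ccc(N2CCN(Cc3cc4cc(c3O)Oc3ccc(cc3)CCc3ccc(CN5CCN(c6ccc(OC)cc6)CC5)c(O)c3-c3ccc(cc3O)CC4)CC2)cc1` (> 20000 nM)
- Compound 3 `O=[N+]([O-])c1cc2cc(c1O)Oc1ccc(cc1)CCc1cccc(O)c1-c1ccc(cc1O)CC2` (> 20000 nM)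

Compound 3 has a limit rather than a number, and it stands at the limit of > 20000 nM in this assay, at which 3 of the 3 values shown sit, with no exact position on the scale.

Compound 4 `CC(=O)Nc1cc2cc(c1O)Oc1ccc(cc1)CCc1cccc(O)c1-c1ccc(cc1O)CC2` keeps the core of compound 3 but carries acetamido in place of nitro, on an aromatic carbon ortho to a hydroxy group: acetamido in place of nitro on an aromatic carbon.

For the measured compounds named here, no pair of measured compounds yet shows what a single change does in this assay, so this forecast is cautious. The expected size of a number no higher from compound 3 to compound 4 (the limit leaves the size open) is none beyond the usual scatter, with no direction favoured. Compound 4 is estimated at (20000 nM), with an expected range from (8000 nM) to (50000 nM).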

Compound 4, half-maximal inhibitory concentration: > 20000 nM
Compound 4: a limit, no number; the forecaster's own chance of this, stated with the estimate: 70%; the middle value sits exactly at the limit.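

Compound 3 and compound 4 both give only limits, so no size can be read for the change from nitro to acetamido: the limit of > 20000 nM in this assay, at which 4 of the 4 values shown sit.

The compounds shown leave open which structural change, if any, would bring a value below this limit.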